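This account rests on a few compounds, and the source may have more. Where it says the series, first, only, none or still open, it means among the compounds named here.

Of the compounds shown here, three of one series have been tested in a functional assay on U-87MG ATCC cells (Homo sapiens) for cytotoxicity, read by MTT assay, with a stated time of 72 h; on this read-out higher numbers stand for weaker inhibition and lower numbers for stronger inhibition. Compound 1, `CN(C)CCn1cnnc1-c1cc(Oc2ccc(NC(=O)N/N=C/c3cc(C(C)(C)C)cc(C(C)(C)C)c3O)cc2F)ccn1`, gives 520 nM in this assay. Compound 2, `COc1ccc(/C=N/NC(=O)Nc2ccc(Oc3ccnc(-c4nncn4CCN(C)C)c3)c(F)c2)c(OC)c1OC`, gives 7650 nM, the highest of the two numbers shown, with compound 1 lower and beyond the scatter. Compound 3, `Cn1ncnc1-c1cc(Oc2ccc(NC(=O)N/N=C/c3ccccc3)cc2F)ccn1`, reaches only the limit of > 100000 nM in this assay, a limit rather than a number, as noted in the limit of > 100000 nM in this assay, at which 1 of the 3 values shown sits. Compound 4, `CN(C)CCn1cnnc1-c1cc(Oc2ccc(NC(=O)N/N=C/c3cccc(Cl)c3Cl)cc2F)ccn1`, is not yet measured. It differs from compound 2 in one place: 2,3-dichlorophenyl in place of 2,3,4-trimethoxyphenyl on a carbon with a double bond to nitrogen. A step toward a lower number, beyond the scatter, is expected, shown as a 5.1-fold lower number from compound 2 to compound 4 (0.71 log units; beyond the scatter). For compound 4 the estimate in this assay is 1500 nM, between 400 nM and 6000 nM.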

Compound 4, half-maximal inhibitory concentration: 13200 nM
Compound 4: middle estimate off by 8.8-fold (0.94 log units), on the low side; measured number above the stated range.
By their numbers in this assay, from the lowest: compound 1; then compounds 2 and 4 (each within the scatter of the next). At a limit, above all of these: compound 3.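

Replacing the 2,3,4-trimethoxyphenyl with 2,3-dichlorophenyl on a carbon with a double bond to nitrogen gives, in this assay, a 1.7-fold higher number from compound 2 to compound 4 (0.24 log units; within the scatter). This position therefore accepts a ring carrying two chlorine atoms and no hydrogen-bond acceptors in place of one carrying three oxygen atoms and 3 hydrogen-bond acceptors, with no difference that can be told from the scatter. Nothing measured here gives a reason for this result. On these data alone, whether an amine or a carboxylic acid on this ring would also leave the number unchanged remains open.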